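The compounds below may be only part of what the source reports. "The series", "measured", "known", "first", "only" and "open" are said of these compounds alone.

Measured so far in a functional assay on BJAB cells (Homo sapiens) for antiproliferative activity, with a stated time of 4 days; a higher number here means that more compound is needed for the effect, a lower number that less compound is needed:
- compound 1 `Cc1cc(-c2c(C)nn(-c3nc(-c4ccc(Cl)c(Cl)c4)c(SC(C)C)s3)c2C(=O)O)cc(C)n1`: 580 nM
- compound 2 `Cc1nn(-c2nc(-c3ccc(Cl)c(Cl)c3)c(SC(C)C)s2)c(C(=O)O)c1-c1ccccc1C(F)(F)F`: 5200 nM

Among the compounds with values here, compound 2 gives the highest number of the two measured in this assay; its only neighbour is compound 1, at a lower number, the step being a 9.0-fold higher number from compound 1 to compound 2 (0.95 log units; beyond the scatter). Compound 3 `Cc1nn(-c2nc(-c3ccc(Cl)c(Cl)c3)c(SC(C)C)s2)c(C(=O)O)c1-c1cc(C#N)cc(C(F)(F)F)c1` is the next member. Its change from compound 2 is 3-cyano-5-(trifluoromethyl)phenyl in place of 2-(trifluoromethyl)phenyl on an aromatic carbon.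

Within the data shown here, only one measured step exists, the one from compound 1 to compound 2, and it concerns an exchange of the whole aryl group at this ring carbon rather than a change of its substituents. It shows that this position carries a modest effect, but it gives no direct guide to adding a nitrile or moving the trifluoromethyl. Among the measured compounds shown here, no step, therefore, fixes the direction for compound 3.

For compound 3 the estimate in this assay is 3500 nM, range 900 nM to 14000 nM, corresponding to an expected step of a 1.5-fold lower number from compound 2 to compound 3 (0.17 log units; within the scatter).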

Compound 3, half-maximal effective concentration: 3600 nM
Compound 3: the middle estimate sits 1.0-fold (0.01 log units) below what was measured, within the range that was stated.
By their numbers in this assay, from the lowest: compound 1; then compounds 3 and 2 (each within the scatter of the next).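

In this assay, the exchange of the aryl group gives a 1.4-fold lower number from compound 2 to compound 3 (0.16 log units; within the scatter), so this position shows no measurable difference between 2-(trifluoromethyl)phenyl and 3-cyano-5-(trifluoromethyl)phenyl, although only the latter carries a nitrile. Compound 1 remains apart from both phenyl compounds, with a 6.2-fold higher number from compound 1 to compound 3 (0.79 log units; beyond the scatter) as a second step of this kind at the same aromatic carbon, so the gap to 2,6-dimethylpyridin-4-yl does not rest on compound 2 alone. No measurement at hand accounts for either step.

The compounds shown do not separate the contribution of the nitrile from that of the altered trifluoromethyl placement. As far as these compounds go, it also remains open whether an amine on the phenyl ring, or an unsubstituted pyridin-4-yl, would fall nearer compound 1 or nearer compound 2.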